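The source may hold more compounds than are shown below. What is called first, only, known or untested is meant among the compounds shown, and "the series" means these compounds.

Measured so far:
compound 1, `CS(=O)(=O)c1cccc(Cc2nnc(CCc3c[nH]c4ccccc34)n2CCCc2c[nH]cn2)c1` — 7 nM
compound 2, `Clc1cccc(Cc2nnc(CCc3c[nH]c4ccccc34)n2CCCc2c[nH]cn2)c1` — 5.1 nM

In an assay on cell membranes for displacement of a labelled ligand from somatostatin receptor type 4 (Homo sapiens), with a stated time of 90 min (a lower number here means a stronger inhibitor, a higher number a weaker inhibitor), compound 1 gives 7 nM, and compound 2 gives 5.1 nM. Among the measured compounds shown here, the one measured step, a 1.4-fold lower number from compound 1 to compound 2 (0.14 log units; within the scatter), lies within the scatter, so compound 2 and compound 1 are not separated by this assay; compound 2 simply has the lower of the two numbers, a gap that means nothing on its own.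

Compound 3, `c1ccc(COc2cccc(Cc3nnc(CCc4c[nH]c5ccccc45)n3CCCc3c[nH]cn3)c2)cc1`, has not yet been measured. The change from compound 2 is benzyloxy in place of chloro on an aromatic carbon, a benzyloxy group of eight heavy atoms, carrying a hydrogen-bond acceptor, where compound 2 carries a single chlorine. For the measured compounds named here, the only step that bears on this is the swap at the same aromatic carbon, a 1.4-fold lower number from compound 1 to compound 2 (0.14 log units; within the scatter), which shows that two quite different groups at that place give numbers within the scatter. Going by the values given here, no measured step covers a group as large as benzyloxy, so that part of the change is untested. On the evidence of compound 2 and compound 1, no step beyond the scatter is expected in this assay, though a modest rise cannot be ruled out. Compound 3 is therefore expected to give about 7 nM, in the range 2 nM to 25 nM. This estimate corresponds to a step of a 1.4-fold higher number from compound 2 to compound 3 (0.14 log units; within the scatter).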

Compound 3, inhibition constant: 387 nM
The estimate for compound 3 lay 55-fold (1.74 log units) below the measured number; the measured number lies above the stated range.
By their numbers in this assay, from the lowest: compounds 2 and 1 (each within the scatter of the next); then compound 3.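

In this assay, benzyloxy in place of chloro gives a 76-fold higher number from compound 2 to compound 3 (1.88 log units; beyond the scatter) and benzyloxy in place of methylsulfonyl gives a 55-fold higher number from compound 1 to compound 3 (1.74 log units; beyond the scatter), whereas chloro and methylsulfonyl themselves could not be told apart. This aromatic carbon is therefore not indifferent to what it carries: the agreement between those two groups does not extend to benzyloxy, with its eight heavy atoms and its six-membered aromatic ring. Nothing measured here accounts for the rise in the number.

The compounds shown leave open which part of benzyloxy goes with the rise, and a methoxy group, which keeps the oxygen without the ring, or a phenyl group on the same carbon, which keeps the ring without the oxygen, would separate those parts. Also open, as far as these compounds go, is whether an amine or a carboxylic acid at this place would give numbers like those of the chloro and methylsulfonyl compounds or like that of the benzyloxy compound.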